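Solubility notes: benzofuranyl in place of methylphenyl

A few compounds are considered here, and "the series" means these few. Any claim that something is new, unique, unknown or untested is made for them only; others in the source may bear on it.

The series shares one core, seen in compound 1 `CNC(=O)c1cc(C(=O)NC2CC2)cn(Cc2ccc(C)cc2)c1=O`. Within the data shown here, in a physicochemical assay for solubility (on this read-out lower numbers stand for lower solubility and higher numbers for higher solubility), compound 1 gives 24 ug/mL, the only plain number obtained so far in this read-out. The other measured member is compound 2 `CNC(=O)c1cc(C(=O)NC2CC2)c(C)n(Cc2ccccc2)c1=O`. In this assay compound 2 returns >= 126 ug/mL, which is a limit of the assay rather than a number (the limit of >= 126 ug/mL in this assay, at which 1 of the 2 values shown sits). Among the measured compounds shown here, no pair of measured compounds differs in only one place, so no measured step is available to calibrate what a single structural change does here.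

Compound 3 `CNC(=O)c1cc(C(=O)NC2CC2)cn(Cc2cccc3occc23)c1=O` has not yet been measured in this assay. Relative to compound 1 the change is 1-benzofuran-4-yl in place of 4-methylphenyl on a saturated chain carbon bound to an aromatic nitrogen. For the measured compounds named here, with no measured step for comparison, the expected size is modest: the step of a 1.6-fold lower number from compound 1 to compound 3 (0.20 log units; within the scatter) is expected to lie near the edge of the usual scatter, leaning toward somewhat lower solubility. Compound 3 is therefore estimated at 15 ug/mL, with a range of 5 ug/mL to 50 ug/mL.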

Compound 3, solubility: >= 110 ug/mL
Compound 3: a limit, no number; the forecaster's own chance of this, stated with the estimate: 10%; middle value at least 7.3-fold (0.86 log units) away from the limit.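

In this assay the series now has its first measured step, at the place on a saturated chain carbon bound to an aromatic nitrogen: an at least 4.5-fold higher number from compound 1 to compound 3 (0.66 log units; beyond the scatter), with 1-benzofuran-4-yl in place of 4-methylphenyl. Compound 3 gives >= 110 ug/mL, which is a limit of the assay and not a number, so the step has a lower bound but no upper bound: the limit of >= 110 ug/mL in this assay, at which 1 of the 3 values shown sits. The entering group is the larger of the two by heavy-atom count and brings a five-membered aromatic ring with 1 hetero atom, yet the number goes up in this one pair, so a larger group at this place does not by itself mean a lower number.

One pair cannot separate the oxygen of 1-benzofuran-4-yl from the second ring, and naphthalen-1-yl, which has two six-membered aromatic rings of carbon only and no oxygen, would be the group to set against it. Compound 2 also sits at a limit, so the shown compounds offer no plain number at the upper end of this read-out: the limit of >= 126 ug/mL in this assay, at which 1 of the 3 values shown sits.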